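Thiophen-3-yl in place of pyrazolyl: an expected gain

This account rests on a few compounds, and the source may have more. Where it says the series, first, only, none or still open, it means among the compounds named here.

Compound 1 `CCN(Cc1cc[nH]n1)C(=O)COc1ccc(C)cc1` gives, in an assay on HEK293 cells for agonist activity at transient receptor potential cation channel subfamily M member 8 (Homo sapiens), read by fluorescence and calcium flux, with a stated time of 15 min (a higher number here means that more compound is needed for the effect, a lower number that less compound is needed), the result "not active" (no number reported), so no single number marks where it stands. Going by the values given here, a related compound 2 `CCN(Cc1cccs1)C(=O)COc1ccccc1`, which carries a thiophen-2-yl group and an unsubstituted phenoxy part, gives in this assay a value of 1400 nM; no step between compound 1 and compound 2 is set out here, so only their two results can be compared side by side. The change from compound 1 to compound 3 `CCN(Cc1ccsc1)C(=O)COc1ccc(C)cc1` is thiophen-3-yl in place of 1H-pyrazol-3-yl on a saturated chain carbon bound to an amide-type nitrogen. Since compound 1 shows no activity at all, this step in this assay is expected to move well beyond the scatter, toward a measurable value. Compound 3 is therefore estimated at 1800 nM, with a plausible range of 500 nM to 6000 nM.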

Compound 3, half-maximal effective concentration: 88 nM
Compound 3: middle estimate off by 20-fold (1.31 log units), on the high side; the whole stated range lies above it.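

In this assay, going by these compounds alone, compound 1 reads "not active" (no number reported) and compound 3 gives 88 nM, so no step between compound 1 and compound 3 can be read. Going by these compounds, how much thiophen-3-yl in place of 1H-pyrazol-3-yl alone contributes stays open, and nothing available bears on this result.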